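The compounds below may be only part of what the source reports. "The series", "measured", "known", "first", "only" and "open" are said of these compounds alone.

Compound 1 `CCc1ccc(-c2nn3cc(-c4cccc(N)c4)nc3s2)cc1`, compound 2 `C=C(Br)C(=O)Nc1cccc(-c2cn3nc(-c4ccc(CC)cc4)sc3n2)c1` and compound 3 `C=C(Br)C(=O)Nc1cccc(-c2cn3nc(-c4ccc(Cl)cc4)sc3n2)c1` were tested in a functional assay on HeLa cells (Homo sapiens) for inhibition, read by cell counting, with a stated time of 4 days; on this read-out higher numbers stand for weaker inhibition and lower numbers for stronger inhibition. Compound 1 gives 8100 nM, compound 2 gives 3200 nM and compound 3 gives 3000 nM. The change hydrogen in place of (1-bromoethenyl)carbonyl on a nitrogen on an aromatic ring made the step of a 2.5-fold higher number from compound 2 to compound 1 (0.40 log units; beyond the scatter). The two cores differ by chloro in place of ethyl on an aromatic carbon, which made the step of a 1.1-fold lower number from compound 2 to compound 3 (0.03 log units; within the scatter). Compound 4 `Nc1cccc(-c2cn3nc(-c4ccc(Cl)cc4)sc3n2)c1` has not yet been measured in this assay; it differs from compound 3 by hydrogen in place of (1-bromoethenyl)carbonyl on a nitrogen on an aromatic ring, the same change that turned compound 2 into compound 1. Because compound 2 to compound 1 gave a 2.5-fold higher number from compound 2 to compound 1 (0.40 log units; beyond the scatter), the step from compound 3 to compound 4 is expected to be about a 2.5-fold higher number from compound 3 to compound 4 (0.40 log units; beyond the scatter). Compound 4 is therefore estimated at 7500 nM, with a likely range from 4000 nM to 14000 nM.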

Compound 4, half-maximal inhibitory concentration: 160000 nM
Beside the measured number, compound 4's estimate is 21-fold (1.33 log units) below it, and the stated range ends below it.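

Taking off the (1-bromoethenyl)carbonyl group gives a 53-fold higher number from compound 3 to compound 4 (1.73 log units; beyond the scatter) in this assay, so the size of this step does not carry over from one core to the other: the same change on two cores in this assay, a 2.5-fold higher number (0.40 log units; beyond the scatter) from compound 2 to compound 1 and a 53-fold higher number (1.73 log units; beyond the scatter) from compound 3 to compound 4, 21-fold (1.32 log units) apart, beyond the scatter of two such steps. Read the other way, chloro in place of ethyl gives a 20-fold higher number from compound 1 to compound 4 (1.30 log units; beyond the scatter) once the amino group is free, although the two groups stay within the scatter of each other on the acylated compounds: the same change on two cores in this assay, a 1.1-fold lower number (0.03 log units; within the scatter) from compound 2 to compound 3 and a 20-fold higher number (1.30 log units; beyond the scatter) from compound 1 to compound 4, 21-fold (1.32 log units) apart, beyond the scatter of two such steps. The two changes therefore do not add up across these four compounds, but this does not show why, nor whether the same would hold for any other group on the aromatic ring.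

The compounds shown leave open how an acetyl group on the amino nitrogen would compare with the (1-bromoethenyl)carbonyl group. They also leave open whether a bromo or methoxy group in place of chloro would follow compound 4 or compound 1.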